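This account rests on a few compounds, and the source may have more. Where it says the series, first, only, none or still open, it means among the compounds named here.

Working notes on the series. In a functional assay on MCF7 cells (Homo sapiens) for inhibition, read by MTT assay, with a stated time of 72 h (a lower number here means a stronger inhibitor, a higher number a weaker inhibitor), compound 1 (`Cc1cc2occ(-c3nc(-c4ccccc4)c(-c4ccccc4)n3-c3ccc(Cl)c(Cl)c3)c(=O)c2cc1Cl`) gives 1560 nM and compound 2 (`Cc1cc2occ(-c3nc(-c4ccccc4)c(-c4ccccc4)n3-c3ccc(Br)cc3)c(=O)c2cc1Cl`) gives 1560 nM, so compound 2 stands level with compound 1 at the digits available. Compound 3 (`Cc1cc2occ(-c3nc(-c4ccccc4)c(-c4ccccc4)n3-c3cccc(Cl)c3)c(=O)c2cc1Cl`) is not yet measured. It keeps the shared core and places 3-chlorophenyl in place of 4-bromophenyl on an aromatic nitrogen. Among the compounds with values here, one measured step bears on this change, at the same place on the core: no change at the digits printed from compound 1 to compound 2 (within the scatter). Within the data shown here, no measured compound carries 3-chlorophenyl itself, so the basis is thin, and the range stays wide. On this evidence, no shift beyond the scatter and no direction is expected in this assay, and the estimated step is no change at the digits printed from compound 2 to compound 3 (within the scatter). The estimate for compound 3 is 1560 nM, with an expected range from 700 nM to 3500 nM.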

Compound 3, half-maximal inhibitory concentration: 6250 nM
Beside the measured number, compound 3's estimate is 4.0-fold (0.60 log units) below it; the whole stated range lies below it.
By their numbers in this assay, from the lowest: compounds 1 and 2 (each within the scatter of the next); then compound 3.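

In this assay, this position on the aromatic nitrogen proves sensitive to the phenyl substitution: 3-chlorophenyl in place of 4-bromophenyl gives a 4.0-fold higher number from compound 2 to compound 3 (0.60 log units; beyond the scatter), and hydrogen in place of chloro on an aromatic carbon gives a 4.0-fold higher number from compound 1 to compound 3 (0.60 log units; beyond the scatter). The level reading of compound 1 and compound 2 therefore does not extend to every halogen-bearing phenyl group here, and the chloro that compound 3 lacks relative to compound 1 counts in this assay. No measurement at hand accounts for this shift.

The three compounds cannot separate the identity of the halogen from its place on the ring. Plain phenyl, 4-chlorophenyl or a phenyl bearing a methoxy group or an amine would show how far the trend runs, and whether it holds on the shared core alone remains open.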